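The compounds below may be only part of what the source reports. "The series", "measured", "known", "first", "only" and "open" are said of these compounds alone.

Of the compounds shown here, three share one core and have been measured in an assay on HEK293 cells for agonist activity at Bile acid receptor (Homo sapiens); a lower number here means that less compound is needed, a higher number that more compound is needed for the effect. Compound 1 `CS(=O)(=O)NC(=O)c1ccc(C2CC2c2ccc(OCc3c(-c4c(Cl)cccc4Cl)noc3C3CC3)cc2Cl)cc1` gives 44 nM. Compound 2 `O=C(O)CNC(=O)c1ccc(C2CC2c2ccc(OCc3c(-c4c(Cl)cccc4Cl)noc3C3CC3)cc2Cl)cc1` gives 209 nM. Compound 3 `Cn1nc(C(=O)O)c2ccc(C3CC3c3ccc(OCc4c(-c5c(Cl)cccc5Cl)noc4C4CC4)cc3Cl)cc21` gives 14 nM. Among these three, compound 2 gives the highest number, so it needs the most material for the effect: its nearest neighbour is compound 1, and the furthest is compound 3, both with markedly lower numbers.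

Going by the values given here, only one single-point step is available: a 4.8-fold higher number from compound 1 to compound 2 (0.68 log units; beyond the scatter), where a carboxymethyl replaced a methylsulfonyl on an amide-type nitrogen, and the number rose.

Compound 4 `O=C(NCCS(=O)(=O)O)c1ccc(C2CC2c2ccc(OCc3c(-c4c(Cl)cccc4Cl)noc3C3CC3)cc2Cl)cc1` differs from compound 2 in one place: sulfomethyl in place of carboxy on a saturated chain carbon bound to an amide-type nitrogen. This is not the same exchange as the measured step, but it again trades a carboxylic acid for a sulfur-based acid group, now one bond further out on the chain. Among the compounds with values here, in the one step that bears on it, the sulfonyl-bearing compound 1 gave the lower number than the carboxy-bearing compound 2, so a modest drop in the number is expected for compound 4, of roughly a 1.9-fold lower number from compound 2 to compound 4 (0.28 log units; within the scatter), though a result within the scatter would not surprise. The estimate for compound 4 in this assay is therefore 110 nM, with a likely range from 40 nM to 350 nM.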

Compound 4, half-maximal effective concentration: 1370 nM
Compound 4: the middle estimate sits 12-fold (1.10 log units) below what was measured, outside the stated range (above it).
By their numbers in this assay, from the lowest: compound 3; then compound 1; then compound 2; then compound 4.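

In this assay, the group on the amide-type nitrogen proves sensitive to what ends the chain: sulfomethyl in place of carboxy gives a 6.6-fold higher number from compound 2 to compound 4 (0.82 log units; beyond the scatter), so this exchange moves the number up, not down. Compound 1 and compound 4 both carry sulfur in the group on this nitrogen, yet 2-sulfoethyl in place of methylsulfonyl gives a 31-fold higher number from compound 1 to compound 4 (1.49 log units; beyond the scatter), so the presence of sulfur there does not by itself go with a low number, and how the sulfur group is built and attached matters greatly. No measurement at hand explains why the number rises in either step.

Compound 4 differs from compound 2 in both the end group and the chain length, and the compounds shown cannot tell which of the two drives the rise; a 2-carboxyethyl group on the same nitrogen would keep the carboxylic acid on the longer chain and separate the two. Also open, going by these compounds, is how a chain ending in an amine instead of any acid group would behave at this place.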